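Replacing the Fluorinated Ring of Compound 2 with Cyclohexyl

A few compounds are considered here, and "the series" means these few. Any claim that something is new, unique, unknown or untested is made for them only; others in the source may bear on it.

Of the compounds shown here, three sharing one core have been measured in an ADME assay on microsomes from liver (Mus musculus) for metabolic stability; on this read-out lower numbers stand for a shorter-lived compound and higher numbers for a longer-lived compound. Compound 1 `Cc1cccc(NC(=O)c2nn(C)c(-c3ccccc3)c2C)n1` gives 0.3 h, compound 2 `Cc1cccc(NC(=O)c2nn(C)c(-c3ccc(F)cc3F)c2C)n1` gives 0.633 h, and compound 3 `Cc1cccc(NC(=O)c2nn(C)c(-c3ccc(C(F)(F)F)cc3)c2C)n1` gives 3.23 h. Compound 2 therefore holds the middle place among the three numbers.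

Compound 4 `Cc1cccc(NC(=O)c2nn(C)c(C3CCCCC3)c2C)n1` keeps the core of compound 2 but exchanges one group: cyclohexyl in place of 2,4-difluorophenyl on an aromatic carbon. In words, cyclohexyl, a non-aromatic ring of carbon only, takes the place of 2,4-difluorophenyl.

Among the measured compounds shown here, two measured steps bear on this exchange. The first, with 2,4-difluorophenyl in place of phenyl, is modest: a 2.1-fold higher number from compound 1 to compound 2 (0.32 log units; beyond the scatter). The second, with trifluoromethyl in place of hydrogen on the phenyl ring, is large: an 11-fold higher number from compound 1 to compound 3 (1.03 log units; beyond the scatter). Both fluorine-bearing compounds sit higher than compound 1, and cyclohexyl carries no fluorine either. Neither step swaps an aromatic ring for a non-aromatic one, so the data offer no direct measure of this change. The best guide is compound 1, whose 0.3 h marks the low end of the series.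

A modest drop is expected in this assay, and the estimated step is a 2.1-fold lower number from compound 2 to compound 4 (0.32 log units; beyond the scatter). For compound 4 the estimated half-life is 0.3 h, with an expected range of 0.1 h to 0.9 h.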

Compound 4, half-life: 0.467 h
Compound 4: middle estimate off by 1.6-fold (0.19 log units), on the low side, within the range that was stated.
By their numbers in this assay, from the lowest: compounds 1, 4 and 2 (each within the scatter of the next, the first and the last beyond it); then compound 3.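

In this assay, cyclohexyl in place of 2,4-difluorophenyl gives a 1.4-fold lower number from compound 2 to compound 4 (0.13 log units; within the scatter), and cyclohexyl in place of phenyl gives a 1.6-fold higher number from compound 1 to compound 4 (0.19 log units; within the scatter); both steps lie within the scatter. Among the compounds shown here, this is the first direct look at an aromatic ring giving way to a non-aromatic ring of carbon only at this position, and here that exchange moves the half-life by no more than repeated measurements would, even though compound 1 and compound 2 differ from each other beyond the scatter, so compound 4 cannot be ranked against either of them. Nothing available explains why these rings read so alike, and no outside measurement bears on the result.

Still open, from the compounds shown here alone, is whether trifluoromethyl, which gives an 11-fold higher number from compound 1 to compound 3 (1.03 log units; beyond the scatter) on the phenyl ring, would give a step of similar size if it were carried on the cyclohexyl ring instead. Also open, going by these compounds, is how a ring holding a heteroatom, such as tetrahydropyranyl or piperidinyl, or an open chain such as n-hexyl, would read at this position.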